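Methyl on the side-chain carbon of compound 2

The source may hold more compounds than are shown below. What is called first, only, known or untested is meant among the compounds shown, and "the series" means these compounds.

Compound 2 `OCCOCc1cn(CCNc2nonc2/C(=N/O)Nc2ccc(F)c(Br)c2)nn1` gives 28 nM in an assay on isolated protein for inhibition of Indoleamine 2,3-dioxygenase 1 (Homo sapiens) (a lower number here means a stronger inhibitor, a higher number a weaker inhibitor), and stands as the lowest of the two numbers in hand, though only narrowly. Compound 1 `CC(C)CC(C)(O)c1cn(CCNc2nonc2/C(=N/O)Nc2ccc(F)c(Br)c2)nn1` gives 51 nM in this assay, and the step of a 1.8-fold lower number from compound 1 to compound 2 (0.26 log units; within the scatter) stays within the scatter, so compound 1 and compound 2 cannot be ranked against each other. Compound 3 `CC(OCCO)c1cn(CCNc2nonc2/C(=N/O)Nc2ccc(F)c(Br)c2)nn1` is not yet measured. Its change from compound 2 is methyl in place of hydrogen on a saturated chain carbon bound to an aromatic carbon and an oxygen on a saturated carbon. Going by the values given here, no measured step touches this carbon directly. Among the compounds with values here, the one measured step, which exchanges the whole group on the same aromatic carbon, is small, and adding a methyl is a smaller change than that exchange, so no step beyond the scatter is expected in this assay in either direction. The expected step from compound 2 to compound 3 is a 1.1-fold higher number from compound 2 to compound 3 (0.03 log units; within the scatter). Compound 3 is therefore estimated at 30 nM, with a range from 12 nM to 75 nM.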

Compound 3, half-maximal inhibitory concentration: 134 nM
Compound 3: the middle estimate sits 4.5-fold (0.65 log units) below what was measured; the whole stated range lies below it.
By their numbers in this assay, from the lowest: compounds 2 and 1 (each within the scatter of the next); then compound 3.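

In this assay the saturated chain carbon bound to an aromatic carbon and an oxygen on a saturated carbon proves sensitive to one added methyl (a 4.8-fold higher number from compound 2 to compound 3 (0.68 log units; beyond the scatter)), whereas the exchange of the whole group on the aromatic carbon between compound 1 and compound 2 stayed within the scatter. The size of the change in the group therefore does not track the size of the step in these compounds, and compound 3 also separates from compound 1 (a 2.6-fold higher number from compound 1 to compound 3 (0.42 log units; beyond the scatter)), even though the 1-hydroxy-1,3-dimethylbutyl group of compound 1 carries a methyl of its own, so a methyl on this carbon does not raise the number in every setting. Nothing at hand explains this sensitivity.

Open, on these data alone, is whether an ethyl or a fluorine on this carbon would give a step like that of the methyl. Also open, as far as these compounds go, is whether the step depends on the ether oxygen of the 1-(2-hydroxyethoxy)ethyl group, which an amine in its place would test.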